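The compounds below may be only part of what the source reports. "The series", "measured", "known", "first", "only" and "open" are said of these compounds alone.

Working notes on the series. Compound 1 `O=C1C=C(NCc2ccccc2)C(=O)c2c1nc1n2[C@H]2OC[C@@H](O)[C@H]2OC1` carries a benzylamino group on the shared core. In a functional assay on HeLa cells (Homo sapiens) for inhibition, read by sulforhodamine B assay (a lower number here means a stronger inhibitor, a higher number a weaker inhibitor), compound 1 returns only a limit, > 8000 nM, so for compound 1 no number is known, only the ceiling of the assay (the limit of > 8000 nM in this assay, at which 1 of the 2 values shown sits). Compound 2 `O=C1C(Nc2ccc(Br)cc2)=CC(=O)c2c1nc1n2[C@H]2OC[C@@H](O)[C@H]2OC1` carries a bromophenyl directly on the amine nitrogen; in this assay compound 2 gives 5220 nM. Among the compounds with values here, no pair of measured compounds differs in one place, so no measured step is available to lean on. Compound 3 `O=C1C=C(NC2CCCC2)C(=O)c2c1nc1n2[C@H]2OC[C@@H](O)[C@H]2OC1` follows from compound 1 by cyclopentyl in place of benzyl on an amine nitrogen. Since compound 1 shows only a limit, the step is expected to be none beyond the scatter, a step that the limit leaves unreadable from compound 1 to compound 3, with a fair chance that this assay again reports only a limit. Compound 3 is estimated at 9000 nM in this assay, with a range from 3000 nM to 30000 nM.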

Compound 3, half-maximal inhibitory concentration: > 16000 nM
Compound 3: a limit, no number; the forecaster's own chance of this, stated with the estimate: 55%; middle value at least 1.7-fold (0.24 log units) from the limit.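

In this assay compound 3, like compound 1, returns only a limit, so no step can be read between compound 1 and compound 3. The compounds shown leave open whether cyclopentyl in place of benzyl on an amine nitrogen changes inhibition at all.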